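Swapping methyl for cyano in a cytotoxicity test

This account rests on a few compounds, and the source may have more. Where it says the series, first, only, none or still open, it means among the compounds named here.

Compound 1 `Cc1ccccc1Sc1cccc(N)c1C#N`: > 40000 nM
Compound 2 `Cc1ccc([S+]([O-])c2cccc(N)c2C#N)cc1`: > 200000 nM

Both entries come from a functional assay on MT4 cells (Homo sapiens) for cytotoxicity (a lower number here means a stronger inhibitor, a higher number a weaker inhibitor), and neither is an exact number. Compound 1 gives > 40000 nM, which is a limit of the assay. Compound 2 gives > 200000 nM, which is also a limit. Compound 2 therefore has no exact place on the scale, and the two limits cannot be ranked against each other.

Compound 3 `N#Cc1ccc([S+]([O-])c2cccc(N)c2C#N)cc1` keeps the core of compound 2 but carries cyano in place of methyl on an aromatic carbon, para to a large group (cyano in place of methyl on an aromatic carbon). Among the measured compounds shown here, no measured pair shows what this swap does. The expected change, a number no higher from compound 2 to compound 3 (the limit leaves the size open), is none beyond the scatter, and another limit is quite likely. The estimate for compound 3 is 200000 nM, with an expected range from 60000 nM to 400000 nM.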

Compound 3, half-maximal inhibitory concentration: > 200000 nM
Compound 3: a limit, no number; the forecaster's own chance of this, stated with the estimate: 70%; the middle value sits exactly at the limit.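

In this assay, compound 2 and compound 3 both stop at a limit rather than a number, and no step can be read between them. The compounds shown leave open what cyano in place of methyl does here, and where on the scale either compound really sits.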